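Chloro in Place of Pyrrolidinyl on a Shared Core

This account rests on a few compounds, and the source may have more. Where it says the series, first, only, none or still open, it means among the compounds named here.

Measured so far:
compound 1, `Clc1ccc2c(NCCCOc3nccc(Cl)n3)ccnc2c1`, 1.04
compound 2, `Clc1ccc2c(NCCCNc3nccc(N4CCCC4)n3)ccnc2c1`, 0.756

In a physicochemical assay for lipophilicity, read by HPLC, in phosphate buffer, measured as octanol-water partition, with a stated time of 24 h, at pH 7.4 (on this read-out lower numbers stand for lower lipophilicity and higher numbers for higher lipophilicity), compound 2 gives 0.756, and compound 1 gives 1.04; the two values lie within the usual scatter of each other, so compound 2 cannot be set apart from compound 1. Compound 3, `Clc1ccc2c(NCCCNc3nccc(Cl)n3)ccnc2c1`, has not been measured. It differs from compound 2 in one place: chloro in place of pyrrolidin-1-yl on an aromatic carbon. Among the measured compounds shown here, with no measured step of this kind to rest on, the expected step in this assay is small, at most a slight rise, and likely within the scatter. Compound 3 is therefore estimated at 0.9, in the range 0.4 to 1.4, a step of a number 0.14 log units higher from compound 2 to compound 3 (within the scatter) that is expected.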

Compound 3, distribution coefficient: 0.657
Estimate against measurement, compound 3: 0.24 log units above; measured number inside the range.
By their numbers in this assay, from the lowest: compounds 3, 2 and 1 (each within the scatter of the next, the first and the last beyond it).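

In this assay, chloro in place of pyrrolidin-1-yl on an aromatic carbon gives a number 0.10 log units lower from compound 2 to compound 3 (within the scatter). Among the compounds shown here, this is the first measured step at this position, and it shows that the two groups cannot be told apart here, despite the loss of the whole ring. No measurement here bears on the reason for this result.

Going by these compounds, whether a methoxy group, a carboxylic acid or a longer amine chain at this position would also stay within the scatter remains open. So does whether this change would give a similar step on another core.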